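Oxime oxygen allylation in the pyridinylpiperazine series

The source may report more compounds than this note shows. Statements on the series, on what has been measured and on what is new or still open speak of the compounds shown alone.

Among the measured compounds shown here, compound 1 `O/N=C(\CCN1CCN(c2ccccn2)CC1)c1ccccc1` carries a free oxime hydroxyl on the shared core; in a functional assay on HEK293 cells with D(4) dopamine receptor (Homo sapiens) as the target, read by FLIPR (a higher number here means that more compound is needed for the effect, a lower number that less compound is needed), compound 1 gives 4.4 nM, the lowest of the three numbers so far. Compound 2 `O/N=C(\CCN1CCN(c2ccccn2)CC1)c1cccc(F)c1` gives 17.1 nM and compound 3 `Cc1ccc(O)c(/C(CCN2CCN(c3ccccn3)CC2)=N/O)c1` gives 19.2 nM. Both depart from compound 1 on the aryl side only: a 3.9-fold higher number from compound 1 to compound 2 (0.59 log units; beyond the scatter) and a 4.4-fold higher number from compound 1 to compound 3 (0.64 log units; beyond the scatter), each modest and beyond the scatter, while a 1.1-fold higher number from compound 2 to compound 3 (0.05 log units; within the scatter) stays within it.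

Compound 4 `C=CCO/N=C(\CCN1CCN(c2ccccn2)CC1)c1ccccc1` changes a different place: allyl in place of hydrogen on an oxygen, the oxygen whose other neighbour is the double-bonded nitrogen. For the measured compounds named here, none of the measured steps touches this oxygen; the aryl steps from compound 1 to compound 2 and to compound 3 show only that changes away from the pyridinylpiperazine side cost compound 1 a modest amount, and give no direct guide to capping the oxime hydroxyl with a three-carbon chain.

Going by the values given here, with no anchoring step, the estimate for compound 4 in this assay is set as a modest loss against compound 1, a 3.0-fold higher number from compound 1 to compound 4 (0.47 log units; beyond the scatter), with a wide range. Compound 4 is therefore expected to give about 13 nM, plausibly between 3 nM and 60 nM.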

Compound 4, half-maximal effective concentration: 350 nM
Beside the measured number, compound 4's estimate is 27-fold (1.43 log units) below it, outside the stated range (above it).
By their numbers in this assay, from the lowest: compound 1; then compounds 2 and 3 (each within the scatter of the next); then compound 4.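

Hydroxy to allyloxy is the only change at this oxygen among the compounds shown, and in this assay it gives an 80-fold higher number from compound 1 to compound 4 (1.90 log units; beyond the scatter). That large step stands well apart from the modest aryl steps, a 3.9-fold higher number from compound 1 to compound 2 (0.59 log units; beyond the scatter) and a 4.4-fold higher number from compound 1 to compound 3 (0.64 log units; beyond the scatter), so in this series the allyl group on the oxygen whose other neighbour is the double-bonded nitrogen costs far more than either change on the aryl side. No measurement at hand bears on what lies behind the rise.

This single step cannot separate the effect of losing the oxime hydrogen from the effect of the allyl group itself, and methyl, propyl or a longer chain ending in an amine or a carboxylic acid on the same oxygen would be needed to tell how the number follows the group placed there. As far as these compounds go, it also remains open whether the allyl step carries over to the 3-fluorophenyl of compound 2 or the 2-hydroxy-5-methylphenyl of compound 3, or holds only with the phenyl of compound 1.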